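Removing One Chlorine from a Dichlorophenyl Adenosine Ligand

The source may hold more compounds than are shown below. What is called first, only, known or untested is meant among the compounds shown, and "the series" means these compounds.

Compound 1 `CN1CCN(c2nc(-c3ccc(Cl)c(Cl)c3)nc3[nH]cnc23)CC1`: > 80%
Compound 2 `Clc1ccc(-c2nc(N3CCCCC3)c3nc[nH]c3n2)cc1Cl`: > 80%
Compound 3 `CN1CCN(c2nc(-c3ccccc3O)nc3c2ncn3C)CC1`: 15.3%

Of the compounds shown here, three share a core and have been tested in an assay on cells for displacement of a labelled ligand from adenosine receptor A3 (Homo sapiens), read by scintillation counting and radioligand binding, with a stated time of 180 min, tested at 10 uM; a lower number here means less inhibition, a higher number more inhibition at the concentration tested (going by the name of the read-out). Compound 1 gives > 80%, which is a limit of the assay rather than a number. Compound 2 likewise gives > 80%, again only a limit. Compound 3, which differs from the other two in several places at once, gives 15.3% in this assay. Within the data shown here, the one single-point step, a step that the two limits leave unreadable from compound 1 to compound 2, cannot be sized because of the limit of > 80% in this assay, at which 2 of the 3 values shown sit. Compound 2 therefore stands at the top of what this assay reports, with no number to compare.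

Compound 4 `Clc1cccc(-c2nc(N3CCCCC3)c3nc[nH]c3n2)c1` is yet to be measured. It differs from compound 2 as follows: hydrogen in place of chloro on an aromatic carbon. No measured step touches the chloro group, so nothing shown sizes this change; the only information is that compound 2 sits at the limit. The inhibition number for compound 4 is expected to be somewhat lower, with a step of a number at least 10 percentage points lower from compound 2 to compound 4 (that floor lies within the scatter) that is an estimate of a modest loss. Compound 4 is thus estimated at 70%, within a range of 40% to 90%.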

Compound 4, a percentage reported as inhibition, at one concentration (the size of the read-out at that concentration, not a potency): > 80%
Compound 4 gave a limit, no number; the forecaster's own chance of this, stated with the estimate: 35%; middle value at least 10 percentage points from the limit.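

In this assay compound 4 gives > 80%, which is a limit of the assay and not a number. No size can therefore be read for the change from compound 2 to compound 4: the limit of > 80% in this assay, at which 3 of the 4 values shown sit.

Whether swapping chloro for hydrogen alters inhibition at all, and by how much, stays open in the compounds shown.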